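A few compounds are considered here, and "the series" means these few. Any claim that something is new, unique, unknown or untested is made for them only; others in the source may bear on it.

Measured to date:
compound 1, `Oc1ccc(-c2cc(-c3ccccc3O)cc(-c3cccc(O)c3)n2)cc1`, 5370 nM
compound 2, `Oc1ccc(-c2cc(-c3cccc(O)c3)cc(-c3cccc(O)c3)n2)cc1`, 1940 nM
compound 3, `Oc1cccc(-c2cc(-c3cccc(O)c3)nc(-c3cccc(O)c3)c2)c1`, 4040 nM

In a functional assay on DU-145 cells (Homo sapiens) for cytotoxicity, read by CCK-8 assay, with a stated time of 4 days (on this read-out higher numbers stand for weaker inhibition and lower numbers for stronger inhibition), compound 2 gives the lowest number of the three. Compound 3 lies nearest, with a 2.1-fold higher number from compound 2 to compound 3 (0.32 log units; beyond the scatter); compound 1 lies furthest, with the step of a 2.8-fold lower number from compound 1 to compound 2 (0.44 log units; beyond the scatter), both beyond the scatter.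

Compound 4, `Oc1ccc(-c2cc(-c3cccc(O)c3)cc(-c3ccccc3O)n2)cc1`, is not yet measured. It differs from compound 2 as follows: 2-hydroxyphenyl in place of 3-hydroxyphenyl on an aromatic carbon. Among the compounds with values here, the step that bears on it is the one from compound 1 to compound 2, a 2.8-fold lower number from compound 1 to compound 2 (0.44 log units; beyond the scatter), which exchanged the same pair of groups in the opposite direction, though elsewhere on the shared core. Running that exchange backwards on compound 2 points to a higher number for compound 4 in this assay, of about the same modest size, with some allowance for the fact that the group now enters next to the ring nitrogen rather than where it sat in compound 1. The step from compound 2 to compound 4 is therefore expected to be a 2.3-fold higher number from compound 2 to compound 4 (0.37 log units; beyond the scatter). Compound 4 is accordingly estimated at 4500 nM, within a range of 2000 nM to 10000 nM.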

Compound 4, half-maximal inhibitory concentration: > 50000 nM
Compound 4: a limit, no number (the forecaster's own chance of this, stated with the estimate: 5%); middle value at least 11-fold (1.04 log units) away from the limit.
By their numbers in this assay, from the lowest: compound 2; then compounds 3 and 1 (each within the scatter of the next). At a limit, above all of these: compound 4.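

In this assay, placing 2-hydroxyphenyl next to the ring nitrogen in exchange for 3-hydroxyphenyl gives an at least 25-fold higher number from compound 2 to compound 4 (1.41 log units; beyond the scatter), a large step, whereas the same pair of groups exchanged elsewhere on the shared core gave only a modest one, a 2.8-fold lower number from compound 1 to compound 2 (0.44 log units; beyond the scatter). Going by these compounds, the reading for compound 4 is a limit and not a number, so the true size of its step remains unknown and the printed size is only a minimum: the limit of > 50000 nM in this assay, at which 1 of the 4 values shown sits. The two steps together show that the effect of this exchange does not carry over from one place on the shared core to another, so the place next to the ring nitrogen has to be treated separately from the place changed between compound 1 and compound 2.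

The compounds shown do not settle whether the loss at this place follows from the hydroxyl itself or from any substituent in that ring position, and a 2-methoxyphenyl, 2-aminophenyl or plain phenyl group there would separate these readings. They also leave open how 4-hydroxyphenyl would read at this place, and the data give no cause for the step.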